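This account rests on a few compounds, and the source may have more. Where it says the series, first, only, none or still open, it means among the compounds named here.

Compound 1 `O=C(CSc1nnc(-c2ccncc2)s1)Nc1ccc(Cl)cc1`: in an ADME assay on BHK-21 cells (Mesocricetus auratus) for cytotoxicity, with a stated time of 3 days (a lower number here means that less compound is tolerated, a higher number that more compound is tolerated), compound 1 gives > 50000 nM, which is a limit of the assay.
Compound 2 `O=C(CCSc1nnc(-c2ccncc2)s1)Nc1ccccc1`: in this assay compound 2 gives > 50000 nM, also a limit of the assay.
Compound 3 `CC(CSc1nnc(-c2ccncc2)s1)C(=O)Nc1ccccc1`: in this assay compound 3 gives > 50000 nM, again a limit of the assay.

Compound 2 therefore stands only at a limit in this assay, and the two other values shown are limits too, all sitting at the limit of > 50000 nM in this assay, at which 3 of the 3 values shown sit. Compound 4 `O=C(CCSc1nnc(-c2ccncc2)s1)Nc1c(Cl)cccc1Cl` differs from compound 2 by 2,6-dichlorophenyl in place of phenyl on an amide-type nitrogen. For the measured compounds named here, the only measured step between single-change neighbours, a step that the two limits leave unreadable from compound 2 to compound 3, cannot be read from these limits, so no measured step speaks to the change at the amide-type nitrogen, and no step beyond the usual scatter is expected in this assay in either direction. Compound 4 is estimated at 80000 nM, with a range from 30000 nM to 300000 nM, most likely reported once more as a limit. The step this estimate means, a step that the limit leaves unreadable from compound 2 to compound 4, is expected to stay within the scatter.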

Compound 4, half-maximal cytotoxic concentration: 10300 nM
Compound 4: the middle estimate sits 7.8-fold (0.89 log units) above what was measured; the measured number lies below the stated range.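

The group on the amide-type nitrogen can change the read-out: in this assay, 2,6-dichlorophenyl in place of phenyl gives an at least 4.8-fold lower number from compound 2 to compound 4 (0.68 log units; beyond the scatter), so less compound is tolerated. Earlier compounds could not show this, and compound 4 is the only one shown with a readable number: the limit of > 50000 nM in this assay, at which 3 of the 4 values shown sit.

On these data alone, compound 2 has only a limit, so the full size of this step remains unknown. As far as these compounds go, whether 2,6-dimethylphenyl or an aminophenyl group on the same nitrogen would lower the number too also remains open.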